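Replacing the Oxazole with Isopropyl on the Amide Nitrogen

A few compounds are considered here, and "the series" means these few. Any claim that something is new, unique, unknown or untested is made for them only; others in the source may bear on it.

Of the compounds shown here, three in this set have been tested in an assay on HEK293 cells for agonist activity at transient receptor potential cation channel subfamily M member 8 (Homo sapiens), read by fluorescence and calcium flux, with a stated time of 15 min; a lower number here means that less compound is needed, a higher number that more compound is needed for the effect. Compound 1 `CCN(Cc1cccs1)C(=O)COc1ccc(F)cc1` gives 422 nM, and compound 3 `CCN(Cc1ccco1)C(=O)COc1ccc(C)cc1` gives 489 nM. Compound 2 `Cc1ccc(OCC(=O)N(Cc2cccs2)c2ncco2)cc1` stands apart: in this assay compound 2 gives 0.3 nM, the lowest of the three numbers, and its distance to compound 1 and to compound 3 lies well beyond the usual scatter of such measurements.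

Compound 4 `Cc1ccc(OCC(=O)N(Cc2cccs2)C(C)C)cc1` has not yet been measured. It differs from compound 2 in one place only: isopropyl in place of 1,3-oxazol-2-yl on an amide-type nitrogen. Compounds 1 and 3, which also carry a simple chain rather than a ring on the amide-type nitrogen, sit far above compound 2, so the ring at that position appears to matter in this small set. For that reason the step from compound 2 to compound 4 is expected to go toward a higher number, and by a large margin, a 330-fold higher number from compound 2 to compound 4 (2.52 log units; beyond the scatter). The estimate for compound 4 in this assay is therefore 100 nM, with a range from 10 nM to 1000 nM.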

Compound 4, half-maximal effective concentration: 70 nM
For compound 4 the middle estimate is 1.4-fold (0.15 log units) above the measured one; the measured number falls inside the stated range.
By their numbers in this assay, from the lowest: compound 2; then compound 4; then compounds 1 and 3 (each within the scatter of the next).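

Going by these compounds alone, this is the first pair in the set that differs in one place only, so it isolates the group on the amide-type nitrogen. In this assay isopropyl in place of 1,3-oxazol-2-yl gives a 230-fold higher number from compound 2 to compound 4 (2.37 log units; beyond the scatter) and the rest of the molecule stays the same, so this single position clearly has a large effect on how much compound is needed. The change removes the five-membered aromatic ring and its hydrogen-bond acceptors together, and no measurement at hand separates these features or explains the step.

As far as these compounds go, it remains open whether another ring at this nitrogen, such as phenyl or 1,3-thiazol-2-yl, would also give a low number. A small saturated ring such as cyclopropyl, or a chain ending in an amine, would help show whether aromaticity or the ring's hetero atoms matter here.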